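Stereocentre inversion in a phosphoserine ester series

The source may hold more compounds than are shown below. What is called first, only, known or untested is meant among the compounds shown, and "the series" means these compounds.

Measured so far:
- compound 1, `CCCCCCCCCCCOc1ccccc1CCC(=O)OC[C@H]1OCCC[C@@H]1OP(=O)(O)OC[C@H](N)C(=O)O`: 7.5%
- compound 2, `N[C@@H](COP(=O)(O)O[C@H]1C=CCO[C@@H]1COC(=O)CCc1ccccc1OCc1cccc(Oc2ccccc2)c1)C(=O)O`: 11.5%
- compound 3, `N[C@@H](COP(=O)(O)O[C@@H]1CCCO[C@@H]1COC(=O)CCc1ccccc1OCc1cccc(Oc2ccccc2)c1)C(=O)O`: "not active" (no number reported)

In an assay on HEK293-A cells for agonist activity at putative P2Y purinoceptor 10 (Mus musculus), with a stated time of 1.5 h (on this read-out higher numbers stand for larger maximal responses and lower numbers for smaller maximal responses), compound 1 gives 7.5%. Compound 2 gives 11.5% in this assay, and the two values lie within the scatter of each other, so no order between compound 1 and compound 2 can be read from them. Compound 3 is reported as "not active" (no number reported) in this assay, without a number. All three compounds sit at the low end of the maximal response scale.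

Compound 4, `CCCCCCCCCCCOc1ccccc1CCC(=O)OC[C@H]1OCCC[C@H]1OP(=O)(O)OC[C@H](N)C(=O)O`, is the next compound to be measured. It differs from compound 1 as follows: the two compounds have the same atoms and bonds; at least one stereo element is drawn with a configuration in one of them and without one in the other: 1 of 4 stereo elements differ; a stereocentre at a saturated ring carbon is drawn S in compound 1 and R in compound 4. Going by the values given here, no pair of measured compounds differs only in this stereocentre, so the effect of the inversion is not known from the series. With the maximal response of compound 1 already small, the expected step of a number 0.5 percentage points higher from compound 1 to compound 4 (within the scatter) is none beyond the scatter, in either direction. Compound 4 is therefore estimated at 8% in this assay, with a range from 0% to 20%.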

Compound 4, largest response reached (Emax), in percent of the reference or control that the assay uses: 10.6%
Estimate against measurement, compound 4: 2.6 percentage points below; measured number inside the range.
By their numbers in this assay, from the lowest: compounds 1, 4 and 2 (each within the scatter of the next).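

In this assay, inverting the stereocentre at a saturated ring carbon from S to R gives a number 3.1 percentage points higher from compound 1 to compound 4 (within the scatter). Going by these compounds alone, this is the first pair that differs in one place only, and at this position the change of configuration does not separate the two values, which both stay at the low end of the maximal response scale. One caution applies to reading this pair: the fact that one of compounds 1 and 4 is drawn with a defined configuration and the other without, at the place where they differ

From the compounds shown here alone, whether the same inversion would give a similar result on the other side chain, as carried by compound 3, stays open, since compound 3 is reported without a number. Also open, going by these compounds, is whether an amide in place of the ester, or a phosphonate in place of the phosphate, would give a larger maximal response on this core.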